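Hydroxy to methylsulfanyl in the formalin test

The compounds below may be only part of what the source reports. "The series", "measured", "known", "first", "only" and "open" are said of these compounds alone.

Compound 2 `CCCC[C@@H](N)C(=O)NCc1ccccc1`: > 71 mg/kg
Compound 3 `N[C@H](CCO)C(=O)NCc1ccccc1`: > 67 mg/kg
Compound 1 `NCC(N)C(=O)NCc1ccccc1`: "not determined" (no result reported)

In a functional assay on the whole organism (strain NMRI) for inhibition, with Mus musculus as the target, in the formalin test, with a stated time of 30 min (on this read-out lower numbers stand for an effect already at smaller amounts and higher numbers for an effect only at larger amounts of compound), compound 3 gives > 67 mg/kg, which is a limit of the assay and not a number. Compound 2 gives > 71 mg/kg, likewise a limit. For compound 1 the entry is "not determined" (no result reported), so no result is reported. The step that the two limits leave unreadable from compound 2 to compound 3 therefore cannot be read. Compound 4 `CSCC[C@@H](N)C(=O)NCc1ccccc1` differs from compound 3 by methylsulfanyl in place of hydroxy on a saturated chain carbon, three bonds along the chain from an amine nitrogen and a carbonyl carbon. For the measured compounds named here, the only measured step that bears on this change is left unreadable by the two limits the limit of > 67 mg/kg in this assay, at which 1 of the 3 values shown sits, and (the limit of > 71 mg/kg in this assay, at which 1 of the 3 values shown sits), so no measured step sets a size or a direction for it. Compound 4 is expected to give 80 mg/kg, with a range from 30 mg/kg to 200 mg/kg, an estimated step that the limit leaves unreadable from compound 3 to compound 4 that stays within the scatter and most likely ends again as a limit.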

Compound 4, dose for half-maximal effect: > 76 mg/kg
Compound 4: a limit, no number; the forecaster's own chance of this, stated with the estimate: 70%; the middle value lies beyond the limit too.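

In this assay compound 4 gives > 76 mg/kg, a limit and not a number, so the steps to it from compound 2 and compound 3 cannot be read. The compounds shown leave open the size and direction of the change from hydroxy to methylsulfanyl.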